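A few compounds are considered here, and "the series" means these few. Any claim that something is new, unique, unknown or untested is made for them only; others in the source may bear on it.

Measured in a functional assay on HL-60 cells (Homo sapiens) for antiproliferative activity, read by XTT assay, with a stated time of 72 h; a lower number here means a stronger inhibitor, a higher number a weaker inhibitor:
- compound 1 `C=C(C)CC[C@]1(C)C2=CCC[C@](C)(C[C@@H](O)C3=CC(=O)OC3O)[C@H]2CC[C@H]1C`: 3300 nM
- compound 2 `C=C(C)CC[C@]1(C)C2=CCC[C@](C)(C[C@H](O)C3=CC(=O)OC3O)[C@H]2CC[C@H]1C`: 3200 nM

Compound 2, at 3200 nM, sits within the scatter of compound 1. Going by the values given here, the only measured step, a 1.0-fold lower number from compound 1 to compound 2 (0.01 log units; within the scatter), changes a single stereocentre at a saturated chain carbon and lies within the scatter.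

Compound 3 `C=C(C)CC[C@]1(C)C2=CCC[C@](C)(C[C@@H](O)c3ccoc3)[C@H]2CC[C@H]1C` is not yet measured. Its change is a group of 7 heavy atoms (5 carbon, 2 oxygen; one five-membered aromatic ring with 1 hetero atom) in place of a group of 9 heavy atoms (5 carbon, 4 oxygen; one five-membered non-aromatic ring with 1 hetero atom), on a saturated chain carbon bound to a saturated ring carbon: (furan-3-yl)(hydroxy)methyl enters on a saturated chain carbon bound to a saturated ring carbon. The step of a 1.0-fold lower number from compound 1 to compound 2 (0.01 log units; within the scatter) leaves the five-membered non-aromatic ring in place, so it gives no direct size for this exchange. Among the compounds with values here, no measured compound lacks that ring, so the expectation in this assay is a tentative one, of a weaker inhibitor. The estimated step is a 3.1-fold higher number from compound 2 to compound 3 (0.49 log units; beyond the scatter). The expected value for compound 3 is 10000 nM, with an estimated range of 3500 nM to 30000 nM.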

Compound 3, half-maximal inhibitory concentration: 28700 nM
Estimate against measurement, compound 3: 2.9-fold (0.46 log units) below, within the range that was stated.
By their numbers in this assay, from the lowest: compounds 2 and 1 (each within the scatter of the next); then compound 3.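

In this assay, the place on a saturated chain carbon bound to a saturated ring carbon responds to the group it carries: exchanging the group holding the five-membered non-aromatic ring for (furan-3-yl)(hydroxy)methyl gives a 9.0-fold higher number from compound 2 to compound 3 (0.95 log units; beyond the scatter). The same exchange, read from the other side of the stereocentre, gives an 8.7-fold higher number from compound 1 to compound 3 (0.94 log units; beyond the scatter), so both steps run the same way and lie beyond the scatter, which the stereochemical step alone did not show. No available evidence bears on what drives this loss.

The exchange alters the ring, its aromatic character and its oxygen count at once, so the compounds shown do not separate these contributions. Also open, as far as these compounds go, is how a carboxylic acid, an amine or a longer chain at this place would read in this assay.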